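The source may hold more compounds than are shown below. What is called first, only, known or untested is meant among the compounds shown, and "the series" means these compounds.

Working notes on the series. Among the compounds with values here, compound 1 `NCc1ccccc1-c1nc(N)nc(NCc2ccccc2)n1` is the first member with a number in a functional assay on cells for positive allosteric modulation of G-protein coupled receptor 68 (Homo sapiens), read by a luciferase reporter and cAMP accumulation, with a stated time of 30 min, at pH 6.8 and pH 8.3, in the presence of a further agent that is not named here; on this read-out lower numbers stand for lower potency and higher numbers for higher potency (the scale is a negative logarithm); in this assay compound 1 gives 3.86. Compound 2 `Nc1nc(NCc2ccc(F)cc2)nc(-c2ccccc2CO)n1` is the second; in this assay compound 2 gives 3.97. Within the data shown here, compound 2 and compound 1 sit together within the scatter, so neither is set apart from the other on the numbers so far, and no step between them can be read as a real change.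

Compound 3 `Cc1ccc(CNc2nc(N)nc(-c3ccccc3CO)n2)cc1` is not yet measured. It differs from compound 2 in one place: methyl in place of fluoro on an aromatic carbon. Among the measured compounds shown here, no measured pair shows this change, so there is nothing to carry over; the two numbers known both lie at the low end of the scale and close together. The expectation for compound 3 is therefore a step of a number 0.03 log units higher from compound 2 to compound 3 (within the scatter), not beyond the scatter in either direction. Compound 3 is estimated at 4 in this assay, with a range from 3.6 to 4.4.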

Compound 3, negative logarithm of the antagonist equilibrium constant: 4.38
Compound 3: middle estimate off by 0.38 log units, on the low side; the measured number falls inside the stated range.
By their numbers in this assay, from the lowest: compounds 1 and 2 (each within the scatter of the next); then compound 3.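

In this assay, within the data shown here, the change from 4-fluorobenzyl to 4-methylbenzyl gives the first step that can be read: a number 0.41 log units higher from compound 2 to compound 3 (beyond the scatter), a modest one. The number therefore responds to the group on this aromatic carbon, para to a large group, even though the exchange is one heavy atom for one heavy atom, with no hydrogen-bond donor or acceptor and no net charge on either side. This single pair shows the size and direction of the step for this one change, but nothing shown accounts for it.

Still open, on these data alone, is whether the rise belongs to the methyl group entering or to the fluoro group leaving, and whether a chloro, methoxy, ethyl or trifluoromethyl group on the same carbon would raise the number further or lower it. As far as these compounds go, it is also open whether the same exchange gives a step of similar size on the core of compound 1, where the number would show if the effect carries over to a different partner group.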